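Methoxy for Fluoro on the Benzyl Group

This account rests on a few compounds, and the source may have more. Where it says the series, first, only, none or still open, it means among the compounds named here.

Compound 3 `Nc1cc(N)c2nc(-c3ccccc3)c(NCc3ccc(F)cc3)nc2c1` carries a 4-fluorobenzyl group on the shared core. In a functional assay on SNB-75 cells (Homo sapiens) for inhibition, read by sulforhodamine B assay, with a stated time of 48 h (a higher number here means that more compound is tolerated, a lower number that less compound is tolerated), compound 3 gives only a limit, < 100000 nM, not a number. Two related compounds share that core: compound 2 `COc1ccc(CNc2nc3cc(N)cc(N)c3nc2-c2ccccc2)cc1OC` carries a 3,4-dimethoxybenzyl group, and compound 1 `CCOC(=O)[C@H](CCC(=O)O)NC(=O)c1ccc(CNc2nc3cc(N)cc(N)c3nc2-c2ccccc2)cc1` carries a longer benzyl-linked amide chain. In this assay compound 2 gives 97700 nM. Compound 1 gives only a limit in this assay, < 100000 nM. The step from compound 2 to compound 3 is a step that the limit leaves unreadable from compound 2 to compound 3, so its size cannot be read. Compound 4 `COc1ccc(CNc2nc3cc(N)cc(N)c3nc2-c2ccccc2)cc1` differs from compound 3 by methoxy in place of fluoro on an aromatic carbon. For the measured compounds named here, no measured step shows what a methoxy in place of a fluoro does here, and the three measured values all sit at or near (the limit of < 100000 nM in this assay, at which 2 of the 3 values shown sit). The step that the estimate means is a step that the limit leaves unreadable from compound 3 to compound 4, expected to be no change beyond the scatter. Compound 4 is expected to give about 95000 nM, between 50000 nM and 150000 nM, and most likely only a limit again.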

Compound 4, concentration lethal to 50% of the cells: 72400 nM
The estimate for compound 4 lay 1.3-fold (0.12 log units) above the measured number; measured number inside the range.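

With the 4-methoxybenzyl group, compound 4 gives a readable number in this assay, so a single methoxy can be set against the 3,4-dimethoxybenzyl group of compound 2. Hydrogen in place of the second methoxy is a 1.3-fold lower number from compound 2 to compound 4 (0.13 log units; within the scatter), so the data do not separate these two compounds. Going by these compounds, compound 3 has only a limit, < 100000 nM, not a number, so the steps from compound 2 to compound 3 and from compound 3 to compound 4 cannot be read, and the effect of methoxy in place of fluoro remains unknown.

The compounds shown leave open whether another group on the benzyl ring, such as an amine or a carboxylic acid, would give a number clearly different from these. The comparisons also remain constrained by one limit: the limit of < 100000 nM in this assay, at which 2 of the 4 values shown sit.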